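A few compounds are considered here, and "the series" means these few. Any claim that something is new, unique, unknown or untested is made for them only; others in the source may bear on it.

Working notes on the series. In a functional assay (strain AB) with Danio rerio as the target, read by microscopy, with a stated time of 1 h (on this read-out higher numbers stand for an effect only at larger amounts of compound and lower numbers for an effect already at smaller amounts), compound 1 (`NC(=O)c1c(NC(=O)Nc2ccc(Cl)cc2)sc2c1CCN(CC1CCCCC1)C2`) reads 1890 nM and compound 2 (`NC(=O)c1c(NC(=O)Nc2ccc(Cl)cc2)sc2c1CCN(CCCNC(=O)CCc1cccnc1)C2`) reads 470 nM on the same scale. Among the measured compounds shown here, compound 2 thus holds the lower of only two numbers, and the gap to compound 1 lies beyond the usual scatter. For the measured compounds named here, no pair of measured compounds differing in one place is available, so the next step has no direct precedent.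

Compound 3 (`CC(C)(C)OC(=O)CCCCCN1CCc2c(sc(NC(=O)Nc3ccc(Cl)cc3)c2C(N)=O)C1`) keeps the core of compound 2 and changes the side chain (2-(tert-butoxycarbonyl)ethyl in place of ((2-(pyridin-3-yl)ethyl)carbonyl)amino on a saturated chain carbon, three bonds along the chain from an amine nitrogen in a ring). On a saturated chain carbon, three bonds along the chain from an amine nitrogen in a ring, 2-(tert-butoxycarbonyl)ethyl replaces ((2-(pyridin-3-yl)ethyl)carbonyl)amino.

The only reference without the side chain of compound 2 is compound 1 at 1890 nM in this assay, so a moderately higher number is expected, though this rests on very little. The estimated change is a 2.1-fold higher number from compound 2 to compound 3 (0.33 log units; beyond the scatter) as a rise of moderate size. For compound 3 the expected value is 1000 nM (estimated range 300 nM to 3500 nM).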

Compound 3, half-maximal effective concentration: 620 nM
Estimate against measurement, compound 3: 1.6-fold (0.21 log units) above; low and high end bracket the measured number.
By their numbers in this assay, from the lowest: compounds 2 and 3 (each within the scatter of the next); then compound 1.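

In this assay the change on a saturated chain carbon, three bonds along the chain from an amine nitrogen in a ring, from ((2-(pyridin-3-yl)ethyl)carbonyl)amino to 2-(tert-butoxycarbonyl)ethyl gives a 1.3-fold higher number from compound 2 to compound 3 (0.12 log units; within the scatter) even though the entering group has no ring and no hydrogen-bond donor, so for this pair neither the pyridine ring nor the amide hydrogen is needed to hold the number at this level. The low number of compound 2 is also no longer tied to a single side chain: replacing cyclohexyl with 4-(tert-butoxycarbonyl)butyl on a saturated chain carbon bound to an amine nitrogen in a ring gives a 3.0-fold lower number from compound 1 to compound 3 (0.48 log units; beyond the scatter). The gap between compound 1 and compound 2 runs in the same direction. No measurement bears on why these two different side chains read alike or why both differ from the cyclohexyl compound.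

Still open, from the compounds shown here alone, is whether a carboxylic acid in place of the tert-butyl ester, a primary amine, or a longer chain would keep the number at this level. All three compounds share one core, so the series says nothing yet about how changes to the core affect the read-out.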